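This account rests on a few compounds, and the source may have more. Where it says the series, first, only, none or still open, it means among the compounds named here.

Of the compounds shown here, two have been tested so far in a functional assay on Caco-2 cells (Homo sapiens) for inhibition, read by MTT assay, with a stated time of 72 h; a higher number here means a weaker inhibitor, a lower number a stronger inhibitor. Compound 1 `CCCNC(=C\C(=O)/C=C/c1ccc(O)c(OC)c1)/C=C/c1ccc(O)c(OC)c1` returns only a limit, > 25000 nM. Compound 2 `CCC(C)NC(=C\C(=O)/C=C/c1ccc(OC(C)=O)c(OC)c1)/C=C/c1ccc(OC(C)=O)c(OC)c1` also returns only a limit, > 25000 nM. Compound 1 therefore has no number of its own, and the whole record comes down to one entry: the limit of > 25000 nM in this assay, at which 2 of the 2 values shown sit. Compound 3 `CCCCNC(=C\C(=O)/C=C/c1ccc(O)c(OC)c1)/C=C/c1ccc(O)c(OC)c1` keeps the core of compound 1 and makes a single change, (methyl in place of hydrogen on a saturated chain carbon, three bonds along the chain from an amine nitrogen), with methyl in place of hydrogen on a saturated chain carbon, three bonds along the chain from an amine nitrogen. Cut one bond further out, this reads propyl to butyl. Within the data shown here, no measured step bears on this change, so no direction can be given, and no step beyond the scatter is expected in this assay. The expected change is a number no higher from compound 1 to compound 3 (the limit leaves the size open). For compound 3 the estimated value is 25000 nM, within an expected range of 10000 nM to 40000 nM.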

Compound 3, half-maximal inhibitory concentration: > 25000 nM
Compound 3 ended at the assay's limit; the forecaster's own chance of this, stated with the estimate: 65%; the middle value sits exactly at the limit.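

Compound 3 returns only a limit in this assay, as compound 1 does, so no step can be read between the two. The compounds shown leave open whether any amine chain on the shared core gives a measurable value in this assay, and how chain length bears on inhibition.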